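Aryl swap on a flat pair

A few compounds are considered here, and "the series" means these few. Any claim that something is new, unique, unknown or untested is made for them only; others in the source may bear on it.

In a functional assay on HL-60 cells (Homo sapiens) for antiproliferative activity, read by MTT assay, with a stated time of 72 h (on this read-out higher numbers stand for weaker inhibition and lower numbers for stronger inhibition), compound 1 `NC1=NC2(CCOCC2)N(OCCCOc2ccc(F)cc2)C(N)=N1` gives 2380 nM and compound 2 `NC1=NC2(CCOCC2)N(OCCCOc2cc(Cl)c(Cl)cc2Cl)C(N)=N1` gives 2360 nM on the same read-out. Going by the values given here, compound 2 therefore stands level with compound 1, the only other measured compound. Among the compounds with values here, the one measured step is a 1.0-fold lower number from compound 1 to compound 2 (0.00 log units; within the scatter) and it puts 2,4,5-trichlorophenyl in place of 4-fluorophenyl on an oxygen on a saturated carbon.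

Compound 3 `NC1=NC2(CCOCC2)N(OCCCOc2ccc(Br)cc2)C(N)=N1` is not yet measured. The change leading to it is 4-bromophenyl in place of 2,4,5-trichlorophenyl on an oxygen on a saturated carbon with 4-bromophenyl in place of 2,4,5-trichlorophenyl on an oxygen on a saturated carbon. Only a 1.0-fold lower number from compound 1 to compound 2 (0.00 log units; within the scatter) bears on this change, as it alters the same group at the same place. Within the data shown here, no measured compound carries 4-bromophenyl, so the expectation rests on a single pair. No shift beyond the scatter is expected, and no direction can be favoured. The expected step is a 1.0-fold higher number from compound 2 to compound 3 (0.01 log units; within the scatter) in this estimate. For compound 3 the estimated value in this assay is 2400 nM with an expected range from 1100 nM to 5000 nM on these grounds.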

Compound 3, half-maximal inhibitory concentration: 310 nM
For compound 3 the middle estimate is 7.7-fold (0.89 log units) above the measured one, outside the stated range (below it).
By their numbers in this assay, from the lowest: compound 3; then compounds 2 and 1 (each within the scatter of the next).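

In this assay, the group on the oxygen on a saturated carbon turns out not to be indifferent: 4-bromophenyl in place of 2,4,5-trichlorophenyl gives a 7.6-fold lower number from compound 2 to compound 3 (0.88 log units; beyond the scatter) and so breaks the flat picture left by the first pair, whose two aryl groups could not be told apart. The smallest change in the set, bromo in place of fluoro on an aromatic carbon, gives a 7.7-fold lower number from compound 1 to compound 3 (0.89 log units; beyond the scatter) with the rest of the molecule untouched, so the identity of a single halogen on that ring is enough to separate compounds here, and compound 3 stands apart from both others by more than the scatter. Nothing available bears on why this one replacement matters in this assay.

The three compounds do not show whether the gain belongs to bromo specifically, since 4-chlorophenyl and 4-iodophenyl would be needed to tell a trend among halogens from a single favourable group. They also leave open how far the result carries beyond aryl ethers of this chain, for instance with a longer chain or with an amine in place of the aryl group.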